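Amide substituent variation in a cytotoxicity series

The source may hold more compounds than are shown below. What is called first, only, known or untested is meant among the compounds shown, and "the series" means these compounds.

Compound 1 `C=CC1=C(C(=O)NCCCCC)C(c2ccc(OC)cc2)OC1` is the reference point of this set. In a functional assay on HeLa cells (Homo sapiens) for cytotoxicity, read by MTT assay, with a stated time of 24 h (a lower number here means a stronger inhibitor, a higher number a weaker inhibitor), compound 1 gives > 100000 nM, which is a limit of the assay and not a number. Compound 2 `C=CC1=C(C(=O)Nc2ccc(OCC)cc2)C(c2ccc(F)cc2)OC1` carries an aryl amide and a fluoro group; in this assay compound 2 gives > 100000 nM, again a limit. Compound 3 `C=CC1=C(C(=O)NCCCCC)C(c2ccc(F)cc2)OC1` keeps the pentyl amide of compound 1; in this assay compound 3 gives > 100000 nM, likewise a limit. The single-point change from compound 1 to compound 3 is a step that the two limits leave unreadable from compound 1 to compound 3, so no step size can be read there. All three values rest on the same line, (the limit of > 100000 nM in this assay, at which 3 of the 3 values shown sit).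

Compound 4 `C=CC1=C(C(=O)NCc2ccccc2F)C(c2ccc(OC)cc2)OC1` is the unmeasured member. It differs from compound 1 by 2-fluorophenyl in place of butyl on a saturated chain carbon bound to an amide-type nitrogen. Going by the values given here, no measured step in this assay gives a readable size; every neighbour sits at the limit, and the change of compound 1 into compound 3 showed nothing that can be read. Compound 4 is therefore expected to remain at the limit as well, with an estimated 200000 nM (range 60000 nM to 800000 nM), the estimate amounting to a step that the limit leaves unreadable from compound 1 to compound 4.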

Compound 4, half-maximal inhibitory concentration: > 100000 nM
Compound 4: only a limit was reported; the forecaster's own chance of this, stated with the estimate: 85%; the middle value does not contradict the limit.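

Replacing the pentyl amide of compound 1 with the 2-fluorobenzyl amide of compound 4 yields no readable step, since both compounds sit at the same assay limit: the limit of > 100000 nM in this assay, at which 4 of the 4 values shown sit.

The compounds shown leave open whether any change to the shared core gives a measurable cytotoxicity value.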